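The source may hold more compounds than are shown below. What is called first, only, known or untested is meant among the compounds shown, and "the series" means these compounds.

Compound 1 `O=C(Nc1ccc(F)c(-c2nc3ncc(-c4cc(F)ccc4F)cc3[nH]2)c1)N1CCCC1`: 2800 nM
Compound 2 `O=C(Nc1ccc(F)c(-c2nc3ncc(-c4ccc(F)cc4F)cc3[nH]2)c1)N1CCCC1`: 9500 nM

In an ADME assay on the whole organism (Mus musculus, strain Swiss Webster) for pharmacokinetics, read by LC-MS, at a dose of 50 mg/kg by the oral route (a higher number here means more compound in the circulation at the dose given, a lower number less compound in the circulation), compound 2 is the higher of the two, at 9500 nM. Compound 3 `O=C(Nc1ccc(F)c(-c2nc3ncc(-c4ccc(F)cc4)cc3[nH]2)c1)N1CCCC1` has hydrogen in place of fluoro on an aromatic carbon, ortho to a large group, 2,4-difluorophenyl to 4-fluorophenyl: hydrogen in place of fluoro on an aromatic carbon. Going by the values given here, no measured step removes a fluoro. Among the compounds with values here, the nearest evidence is a 3.4-fold higher number from compound 1 to compound 2 (0.53 log units; beyond the scatter), which shows only that this ring's fluoro pattern can move the read-out. A change of similar size is therefore expected, with its direction poorly defined. The expected change, leaning lower, is a 1.6-fold lower number from compound 2 to compound 3 (0.20 log units; within the scatter). For compound 3 the estimated value is 6000 nM, with an expected range of 2000 nM to 18000 nM.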

Compound 3, maximal plasma concentration: 6270 nM
The estimate for compound 3 lay 1.0-fold (0.02 log units) below the measured number, and the stated range covers the measured number.
By their numbers in this assay, from the lowest: compound 1; then compounds 3 and 2 (each within the scatter of the next).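

In this assay hydrogen in place of fluoro, ortho to a large group, gives a 1.5-fold lower number from compound 2 to compound 3 (0.18 log units; within the scatter) and so the fluoro at this position is not needed to hold the read-out at this level. The 4-fluorophenyl ring also gives a 2.2-fold higher number from compound 1 to compound 3 (0.35 log units; beyond the scatter) and leaves the 2,5-difluorophenyl ring as the only one of the three set apart by its number. Nothing available explains these differences.

Open, as far as these compounds go, is whether another group on this carbon, such as methoxy, an amine or a carboxylic acid, keeps the read-out at this level.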